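From a diethylamino chain to a 4-(trifluoromethoxy)phenyl group

The source may report more compounds than this note shows. Statements on the series, on what has been measured and on what is new or still open speak of the compounds shown alone.

Compound 1 `CCN(CC)CCNC(=O)c1ccc(C(CC)(CC)c2ccc(OCCC(O)(CC)CC)c(C)c2)n1CC`: 550 nM
Compound 2 `CCn1c(C(=O)NCC#N)ccc1C(CC)(CC)c1ccc(OCCC(O)(CC)CC)c(C)c1`: > 50000 nM (a limit)
Compound 3 `C#CC(C)OC(=O)c1ccc(C(CC)(CC)c2ccc(OCCC(O)(CC)CC)c(C)c2)n1CC`: > 50000 nM (a limit)

Among the compounds with values here, in a functional assay on MCF7 cells (Homo sapiens) for antiproliferative activity, read by MTT assay, with a stated time of 48 h (a higher number here means a weaker inhibitor, a lower number a stronger inhibitor), compound 1 gives 550 nM, the only actual number and the strongest result of the three. The readings of compound 2 and compound 3 are limits. Compound 4 `CCn1c(C(=O)Nc2ccc(OC(F)(F)F)cc2)ccc1C(CC)(CC)c1ccc(OCCC(O)(CC)CC)c(C)c1` changes the same side chain of compound 1: 4-(trifluoromethoxy)phenyl in place of 2-(diethylamino)ethyl on an amide-type nitrogen. The diethylamino end is lost, as it was in two measured changes, both large: an at least 90-fold higher number from compound 1 to compound 2 (1.95 log units; beyond the scatter) and an at least 90-fold higher number from compound 1 to compound 3 (1.95 log units; beyond the scatter). Only these two changes support the trend, and neither introduces the new ring. A large move toward weaker inhibition is therefore expected: a 36-fold higher number from compound 1 to compound 4 (1.56 log units; beyond the scatter). For compound 4, the estimated value is 20000 nM, with an expected range of 4000 nM to 50000 nM.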

Compound 4, half-maximal inhibitory concentration: > 50000 nM
Compound 4: no number, only a limit; the forecaster's own chance of this, stated with the estimate: 50%; middle value at least 2.5-fold (0.39 log units) from the limit.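

Placing an aromatic ring on the amide-type nitrogen does not recover the activity of compound 1, even with the amide kept: the change gives an at least 90-fold higher number from compound 1 to compound 4 (1.95 log units; beyond the scatter). The reading of compound 4 is a limit, not a number. The steps among compounds 2, 3 and 4 cannot be read, because all three stop at the same limit: the limit of > 50000 nM in this assay, at which 3 of the 4 values shown sit.

Still open, from the compounds shown here alone, is whether the amine itself is what counts. A dimethylamino end on the same chain, or a plain butyl chain with no amine, would separate the amine from the chain.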